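A sulfonyl aryl swap whose outcome is still open

A few compounds are considered here, and "the series" means these few. Any claim that something is new, unique, unknown or untested is made for them only; others in the source may bear on it.

Measured compounds:
compound 1 `COc1cc(C)c(Cl)cc1S(=O)(=O)n1c(C)c(/C=N/N2CCN(C)CC2)c2ccccc21`: 2400 nM
compound 2 `CN1CCN(/N=C/c2c(-c3ccccc3)n(S(=O)(=O)c3ccccc3)c3ccccc23)CC1`: 1800 nM

In a functional assay on HEK293 cells for antagonist activity at 5-hydroxytryptamine receptor 6 (Homo sapiens), read by cAMP accumulation, with stated times of 10 min and 1 h (on this read-out lower numbers stand for stronger inhibition and higher numbers for weaker inhibition), compound 1 gives 2400 nM and compound 2 gives 1800 nM. Compound 2 holds the lower of the two numbers, but its gap to compound 1 lies within the scatter, so the two cannot be ranked against each other. They also differ in two places at once, so no single step can be read from this pair.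

Compound 3 `COc1cc(C)c(Cl)cc1S(=O)(=O)n1c(-c2ccccc2)c(/C=N/N2CCN(C)CC2)c2ccccc21` carries the change (5-chloro-2-methoxy-4-methylphenyl in place of phenyl on a sulfonyl sulfur). Among the measured compounds shown here, no measured pair isolates this change; compound 1 bears the same sulfonyl aryl group yet differs elsewhere, so it offers no clean reference. The step of no change at the digits printed from compound 2 to compound 3 (within the scatter) is therefore expected to remain within the scatter, with no clear direction. For compound 3 the estimate in this assay is 1800 nM, with a range from 600 nM to 5500 nM.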

Compound 3, half-maximal inhibitory concentration: 7400 nM
The estimate for compound 3 lay 4.1-fold (0.61 log units) below the measured number, outside the stated range (above it).
By their numbers in this assay, from the lowest: compounds 2 and 1 (each within the scatter of the next); then compound 3.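

In this assay, the aryl group on a sulfonyl sulfur whose other neighbour is the aromatic nitrogen matters: 5-chloro-2-methoxy-4-methylphenyl in place of phenyl gives a 4.1-fold higher number from compound 2 to compound 3 (0.61 log units; beyond the scatter), a modest step beyond the scatter. The aromatic carbon that changes between compound 1 and compound 3 matters as well, since phenyl in place of methyl there gives a 3.1-fold higher number from compound 1 to compound 3 (0.49 log units; beyond the scatter), also modest and beyond the scatter. Nothing available explains either step.

On these data alone, each change is seen only once, on a single background, so it remains open whether the sulfonyl aryl swap would have the same effect with methyl rather than phenyl on the aromatic carbon. As far as these compounds go, how a pyridine or a thiophene ring would fare on the sulfonyl sulfur also remains open.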